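This account rests on a few compounds, and the source may have more. Where it says the series, first, only, none or still open, it means among the compounds named here.

Within the data shown here, compound 1 `N#Cc1cnc(NCc2cnccc2C(F)(F)F)cc1N[C@H]1C[C@@H](O)C1` is one of two compounds measured in an assay on isolated protein for inhibition of protein kinase C theta type (Homo sapiens), read by TR-FRET, with a stated time of 2 h; a higher number here means a weaker inhibitor, a lower number a stronger inhibitor: compound 1 gives 500 nM, the highest of the two numbers, while compound 2 `N#Cc1cnc(NCc2cnccc2C(F)(F)F)cc1NC[C@H]1CC[C@@H](O)CC1` gives 58 nM, a step of an 8.6-fold lower number from compound 1 to compound 2 (0.94 log units; beyond the scatter). Compound 3 `CNC(=O)[C@H]1CC[C@@H](Nc2cc(NCc3cnccc3C(F)(F)F)ncc2C#N)CC1` is not yet measured. It differs from compound 1 in one place (4-(methylcarbamoyl)cyclohexyl in place of 3-hydroxycyclobutyl on a nitrogen on an aromatic ring). Among the measured compounds shown here, the only measured step that bears on this change is the one from compound 1 to compound 2, where a six-membered ring with a hydroxyl replaced the 3-hydroxycyclobutyl and the number fell by an 8.6-fold lower number from compound 1 to compound 2 (0.94 log units; beyond the scatter). Compound 3 also replaces the 3-hydroxycyclobutyl with a six-membered ring carrying a donor and an acceptor, so a drop of similar size in this assay is expected, though with less certainty since the group is attached without a methylene and carries a methylcarbamoyl rather than a hydroxyl. Compound 3 is therefore estimated at 100 nM (range 30 nM to 400 nM), a step of a 5.0-fold lower number from compound 1 to compound 3 (0.70 log units; beyond the scatter).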

Compound 3, half-maximal inhibitory concentration: 27 nM
Beside the measured number, compound 3's estimate is 3.7-fold (0.57 log units) above it, and the stated range ends above it.
By their numbers in this assay, from the lowest: compound 3; then compound 2; then compound 1.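

In this assay, 4-(methylcarbamoyl)cyclohexyl on the nitrogen gives a 19-fold lower number from compound 1 to compound 3 (1.27 log units; beyond the scatter), a larger step at this position than the one seen earlier. It also goes further than (4-hydroxycyclohexyl)methyl, with a 2.1-fold lower number from compound 2 to compound 3 (0.33 log units; beyond the scatter). Among these compounds, then, the lowest number at this position comes from a six-membered ring with a methylcarbamoyl group rather than a hydroxyl, so a hydroxyl is not required here for a number of this size.

No measurement shown accounts for either step. It remains open how much of the gain belongs to the ring and how much to the methylcarbamoyl group, as an unsubstituted cyclohexyl and a cyclohexyl carrying a hydroxyl, a carboxylic acid or an amine are not among the compounds shown.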